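This account rests on a few compounds, and the source may have more. Where it says the series, first, only, none or still open, it means among the compounds named here.

Going by the values given here, compound 2 `Cc1cc(NCC2CCCCN2)n2nc(C)c(-c3ccccc3)c2n1` holds the only number in a physicochemical assay for solubility, read by HPLC, using the shake flask method, measured as kinetic solubility, with a stated time of 2 h, at pH 7.4 (on this read-out lower numbers stand for lower solubility and higher numbers for higher solubility), where compound 2 gives 189000 nM. Compound 1 `Cc1cc(NCc2cccs2)n2nc(C)c(-c3ccccc3)c2n1` gives < 5000 nM in this assay, which is a limit rather than a number. The measured step of an at least 37-fold higher number from compound 1 to compound 2 (1.57 log units; beyond the scatter) is thus bounded from below only, resting on (the limit of < 5000 nM in this assay, at which 1 of the 2 values shown sits). Compound 3 `CCN1CCCC1CNc1cc(C)nc2c(-c3ccccc3)c(C)nn12` differs from compound 2 by 1-ethylpyrrolidin-2-yl in place of piperidin-2-yl on a saturated chain carbon bound to a nitrogen on an aromatic ring. Among the compounds with values here, the ring nitrogen and its acceptor remain while the donor is lost, so no step of the earlier size is expected; a modest change, a 1.6-fold lower number from compound 2 to compound 3 (0.20 log units; within the scatter), is expected. Compound 3 is estimated at 120000 nM, within 40000 nM to 300000 nM.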

Compound 3, solubility: 172000 nM
For compound 3 the middle estimate is 1.4-fold (0.16 log units) below the measured one; measured number inside the range.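

In this assay, 1-ethylpyrrolidin-2-yl in place of piperidin-2-yl on a saturated chain carbon gives a 1.1-fold lower number from compound 2 to compound 3 (0.04 log units; within the scatter), so neither the change of ring size nor the loss of the ring's hydrogen-bond donor moves the read-out beyond the scatter. Against thiophen-2-yl, this second nitrogen-bearing ring also gives a large step, an at least 34-fold higher number from compound 1 to compound 3 (1.53 log units; beyond the scatter). That step rests on a limit and not on a number: the limit of < 5000 nM in this assay, at which 1 of the 3 values shown sits.

Going by these compounds, whether the ring nitrogen itself carries these steps stays open, and cyclohexyl in this place would test it. On these data alone, how a carboxylic acid there would read also stays open.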